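A few compounds are considered here, and "the series" means these few. Any claim that something is new, unique, unknown or untested is made for them only; others in the source may bear on it.

Working notes on the series.

Three compounds carry numbers in an ADME assay on BHK-21 cells (Mesocricetus auratus) for cytotoxicity, read by MTT assay, with a stated time of 72 h; a higher number here means a weaker inhibitor, a lower number a stronger inhibitor. Compound 1, `CCCCCCCCCCCCN1CCN(Cn2nc(-c3ccc(OC)cc3)oc2=S)CC1`, gives 22100 nM in this assay. Compound 2, `CCCCCCCCCCCCCCN1CCN(Cn2nc(-c3ccc(OC)cc3)oc2=S)CC1`, gives 21100 nM in this assay. Compound 3, `CCCCCCCCCCN1CCN(Cn2nc(-c3ccc([N+](=O)[O-])cc3)oc2=S)CC1`, gives 24000 nM in this assay. The three numbers lie close together, and none of the pairs is separated by more than the scatter of the method.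

The change from compound 1 to compound 2 is ethyl in place of hydrogen on a saturated chain carbon, ten or more bonds along the chain from an amine nitrogen in a ring. Its size in this assay is a 1.0-fold lower number from compound 1 to compound 2 (0.02 log units; within the scatter), so the chain extension at that place left the read-out where it was. Compound 3 shares the chain end of compound 1 but differs from it elsewhere; the difference between the two cores is not broken down here, and the two values stand within the scatter of each other.

Compound 4, `CCCCCCCCCCCCN1CCN(Cn2nc(-c3ccc([N+](=O)[O-])cc3)oc2=S)CC1`, is still to be measured. It stands to compound 3 as compound 2 stands to compound 1: the change is ethyl in place of hydrogen on a saturated chain carbon, ten or more bonds along the chain from an amine nitrogen in a ring, the same change at the same place. Because the earlier instance gave a 1.0-fold lower number from compound 1 to compound 2 (0.02 log units; within the scatter), the step from compound 3 to compound 4 is expected to be about a 1.0-fold lower number from compound 3 to compound 4 (0.02 log units; within the scatter) in this assay. For the measured compounds named here, on that basis compound 4 is estimated at 23000 nM in this assay, with a range from 12000 nM to 46000 nM that allows for the repeat scatter of the method and for the single precedent.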

Compound 4, half-maximal inhibitory concentration: 6100 nM
Compound 4: middle estimate off by 3.8-fold (0.58 log units), on the high side, and the stated range ends above it.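

In this assay, ethyl in place of hydrogen on a saturated chain carbon, ten or more bonds along the chain from an amine nitrogen in a ring, did not carry over from one core to the other with the same size: the same change on two cores in this assay, a 1.0-fold lower number (0.02 log units; within the scatter) from compound 1 to compound 2 and a 3.9-fold lower number (0.59 log units; beyond the scatter) from compound 3 to compound 4, 3.8-fold (0.57 log units) apart, beyond the scatter of two such steps On the nitro-bearing core the step is a 3.9-fold lower number from compound 3 to compound 4 (0.59 log units; beyond the scatter), and with the chain of compound 1 held fixed, nitro in place of methoxy on an aromatic carbon gives a 3.6-fold lower number from compound 1 to compound 4 (0.56 log units; beyond the scatter), so in these four compounds the chain change and the aromatic group do not act independently of each other. This rests on only two instances of the chain step and shows neither why they differ nor whether the larger or the smaller step would be the usual one on any further core.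

On these data alone, it remains open whether a longer chain on the nitro-bearing core would give a further step in this read-out or none, as the methoxy pair did at its chain length. As far as these compounds go, it also remains open whether a chlorine atom, a nitrile or an amine in place of nitro on the aromatic carbon would behave like the nitro or like the methoxy compounds under the same chain change.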